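This account rests on a few compounds, and the source may have more. Where it says the series, first, only, none or still open, it means among the compounds named here.

The series shares one core across compound 1 `C(=N/OCc1ccccc1)\c1c(-c2ccc3ccccc3c2)nc2occn12`, compound 2 `CC(C)c1ccc(-c2nc3sccn3c2/C=N/OCc2ccc(Cl)c(Cl)c2)cc1` and compound 3 `Clc1ccc(CO/N=C/c2c(-c3ccc4ccccc4c3)nc3occn23)c(Cl)c1`. In an assay on HepG2 cells for agonist activity at nuclear receptor subfamily 1 group I member 3 (Homo sapiens), read by a luciferase reporter, with a stated time of 23 h (on this read-out lower numbers stand for an effect already at smaller amounts and higher numbers for an effect only at larger amounts of compound), compound 1 gives 840 nM, compound 2 gives 590 nM and compound 3 gives 1500 nM. Compound 2 holds the lowest of the three numbers; its gap to compound 1 lies within the scatter, its gap to compound 3 beyond it. Within the data shown here, the only single-point step among the measured compounds, a 1.8-fold higher number from compound 1 to compound 3 (0.25 log units; within the scatter), concerns the ring on the saturated chain carbon bound to an oxygen, not the six-membered aromatic ring of carbon only attached to the core.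

Compound 4 `Cc1ccc(-c2nc3sccn3c2/C=N/OCc2ccc(Cl)c(Cl)c2)cc1` is not yet measured. It differs from compound 2 by methyl in place of isopropyl on an aromatic carbon. Among the measured compounds shown here, no measured step touches this position, so the data give no direct guide to the size or direction of the step; the one measured step elsewhere stayed within the scatter. Compound 4 is therefore expected to stay close, with the step of a 1.4-fold higher number from compound 2 to compound 4 (0.13 log units; within the scatter) expected to remain within the scatter. Compound 4 is estimated at 800 nM, between 300 nM and 2500 nM.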

Compound 4, half-maximal effective concentration: 490 nM
The estimate for compound 4 lay 1.6-fold (0.21 log units) above the measured number; low and high end bracket the measured number.
By their numbers in this assay, from the lowest: compounds 4, 2, 1 and 3 (each within the scatter of the next, the first and the last beyond it).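

In this assay, the place on the six-membered aromatic ring of carbon only, para to a large group, now has its first measured step: a 1.2-fold lower number from compound 2 to compound 4 (0.08 log units; within the scatter). Going from 4-isopropylphenyl to 4-methylphenyl, with 3 heavy atoms replaced by 1, therefore stays within the scatter on the rest of compound 2, and this single pair says nothing about the same change on the core of compound 1. No measured information bears on why the step is this small.

The compounds shown carry only these two hydrocarbon groups at this place, so it remains open how a carboxylic acid, an amine or a longer chain such as hexyl would read there. Also open, on these data alone, is whether a second change elsewhere on compound 4, such as phenyl in place of the dichlorinated ring on the chain carbon bound to an oxygen, would give a step beyond the scatter.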